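The source may report more compounds than this note shows. Statements on the series, on what has been measured and on what is new or still open speak of the compounds shown alone.

Of the compounds shown here, two from one series have been measured in a functional assay on the whole organism (strain albino) for inhibition, with Rattus norvegicus as the target, read by paw edema, with a stated time of 1 h, at a dose of 0.029 mmol/kg by the oral route; a lower number here means less inhibition, a higher number more inhibition at the dose given (going by the name of the read-out). Compound 1, with the structure `N#CC1=C(NCCN)N(c2ccccc2)C(=O)N2CCCC12`, gives 15.7% in this assay. Compound 2, with the structure `NC1=C(/C(N)=N\O)C2CCCN2C(=O)N1c1ccccc1`, gives 4.45% in this assay, the lower of the two numbers, and its nearest neighbour is compound 1, whose number lies higher by more than the usual scatter.

The piece now follows a single change from compound 2 to compound 3, whose structure is `N/N=C(/N)C1=C(N)N(c2ccccc2)C(=O)N2CCCC12` and which has not yet been measured in this assay. The difference between the two structures is amino in place of hydroxy on a double-bonded nitrogen. Among the compounds with values here, no pair of measured compounds differs in just one place, so there is no earlier step of this kind to lean on; the change is small, with one heavy atom leaving and one entering and no change in the count of hydrogen-bond donors or acceptors.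

The step of a number 3.6 percentage points higher from compound 2 to compound 3 (within the scatter) is therefore expected to stay within the usual scatter, with no clear direction. For compound 3 the estimated value in this assay is 8%, with a likely range from -5% to 22%.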

Compound 3, a percentage reported as inhibition, in the whole organism at one dose (the size of the read-out at that dose, not a potency): 8.97%
Beside the measured number, compound 3's estimate is 1 percentage points below it, within the range that was stated.
By their numbers in this assay, from the lowest: compounds 2, 3 and 1 (each within the scatter of the next, the first and the last beyond it).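

Within the data shown here, replacing hydroxy with amino on a double-bonded nitrogen gives the first direct comparison at this position: in this assay the change is a number 4.5 percentage points higher from compound 2 to compound 3 (within the scatter) and so cannot be told apart from the variation expected between repeated measurements. At this single dose and time, then, the paw edema read-out does not separate the two groups, which exchange one heavy atom for another and have the same counts of hydrogen-bond donors and acceptors. No measured information on the properties of these groups accompanies the result, so the data cannot explain this likeness.

As far as these compounds go, what a methoxy or a dimethylamino group would do in this same place remains open, as does whether hydroxy and amino would still look alike at other doses or read times. Compound 1 differs from compound 2 and compound 3 in more than one place, so it cannot show how any single change at this position relates to its number.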